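Replacing a Chloro Group with Methylsulfonyl in a Quinolone-Type Series

The compounds below may be only part of what the source reports. "The series", "measured", "known", "first", "only" and "open" are said of these compounds alone.

Compound 1, with the structure `O=c1c(-c2nn[nH]n2)c[nH]c2c(Cl)cccc12`, is the anchor of this small set. Among the compounds with values here, in a functional assay on the whole organism (strain Sprague-Dawley) for inhibition, with Rattus norvegicus as the target (a higher number here means that more compound is needed for the effect, a lower number that less compound is needed), compound 1 gives 0.078 mg/kg, the only outright number among the three values shown. Compound 2, `O=c1c(-c2nn[nH]n2)c[nH]c2c(Cl)ccc(Cl)c12`, reaches only a limit of the assay, reported as > 0.156 mg/kg. Compound 3, `O=c1c(-c2nn[nH]n2)c[nH]c2c(Cl)c(Cl)ccc12`, likewise stops at a limit, > 0.156 mg/kg. Both of these carry a second chloro group, and the steps read an at least 2.0-fold higher number from compound 1 to compound 2 (0.30 log units; that floor lies within the scatter) and an at least 2.0-fold higher number from compound 1 to compound 3 (0.30 log units; that floor lies within the scatter), so adding a chloro group appears to raise the dose needed, though the floor of each step sits within the scatter. Two of the three values thus sit at the limit of > 0.156 mg/kg in this assay, at which 2 of the 3 values shown sit.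

Compound 4, `CS(=O)(=O)c1cccc2c(=O)c(-c3nn[nH]n3)c[nH]c12`, is not yet measured. It differs from compound 1 by methylsulfonyl in place of chloro on an aromatic carbon. This is a swap rather than an addition, so the two measured steps bear on it only loosely; they show that changing the halogen pattern of the core of compound 1 tends toward a higher number, and the new group is larger than the one it replaces. In this assay compound 4 is therefore expected to need a somewhat higher dose, with the step of a 1.9-fold higher number from compound 1 to compound 4 (0.28 log units; within the scatter) reckoned as modest and uncertain. My estimate for compound 4 in this assay is 0.15 mg/kg, lying between 0.05 mg/kg and 0.5 mg/kg.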

Compound 4, minimum effective dose: 10 mg/kg
Estimate against measurement, compound 4: 67-fold (1.82 log units) below, outside the stated range (above it).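

In this assay, putting methylsulfonyl in place of chloro gives a 130-fold higher number from compound 1 to compound 4 (2.11 log units; beyond the scatter), so what sits on this aromatic carbon, ortho to a fused ring, matters a great deal. The earlier compounds shown here kept this chloro and gained a second chloro group, and their values are limits. Within the data shown here, their steps show only a floor within the scatter, whereas this is the only step in the set with a full size, and it lies beyond the scatter. The step cannot tell whether the four heavy atoms entering in place of one or the two hydrogen-bond acceptors they bring count for more, and nothing measured here gives a reason for the change.

Still open, from the compounds shown here alone, is whether the large step comes from losing chloro or from gaining methylsulfonyl, which a methyl group, a fluoro group or a methoxy group on the same carbon could help to separate. Also open, going by these compounds, is how far compound 2 and compound 3 truly lie from compound 1, since both stop at a limit of the assay.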